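The source may hold more compounds than are shown below. What is called first, only, known or untested is meant among the compounds shown, and "the series" means these compounds.

Measured compounds:

compound 1 `CCC(=O)Nc1c(C(O)(C(F)(F)F)C(F)(F)F)ccc2ccccc12`: 15 nM
compound 2 `CC(C)=CC(=O)Nc1c(C(O)(C(F)(F)F)C(F)(F)F)ccc2ccccc12`: 46 nM
compound 3 `COc1cccc(C(=O)Nc2c(C(O)(C(F)(F)F)C(F)(F)F)ccc3ccccc23)c1`: 185 nM

In an assay on LtK cells with ATP-sensitive inward rectifier potassium channel 11 (Homo sapiens) as the target (a lower number here means that less compound is needed, a higher number that more compound is needed for the effect), compound 3 gives the highest number of the three: compound 2 is nearest to it with a 4.0-fold higher number from compound 2 to compound 3 (0.60 log units; beyond the scatter) read backwards, and compound 1 furthest, with a 12-fold higher number from compound 1 to compound 3 (1.09 log units; beyond the scatter). Within the measured set every departure from the ethyl of compound 1 on the carbonyl carbon raised the number: a 3.1-fold higher number from compound 1 to compound 2 (0.49 log units; beyond the scatter) for the branched alkenyl group, and the larger aryl group of compound 3 raised it further, a 4.0-fold higher number from compound 2 to compound 3 (0.60 log units; beyond the scatter).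

Compound 4 `O=C(Nc1c(C(O)(C(F)(F)F)C(F)(F)F)ccc2ccccc12)c1cnco1` differs from compound 3 in one place: 1,3-oxazol-5-yl in place of 3-methoxyphenyl on a carbonyl carbon.

Among the compounds with values here, no measured step covers an aromatic heterocycle on this carbonyl carbon, so the step of a 4.0-fold higher number from compound 2 to compound 3 (0.60 log units; beyond the scatter) and the step of a 12-fold higher number from compound 1 to compound 3 (1.09 log units; beyond the scatter) are the only bearings, and they only show that the aryl amide of compound 3 sits at the unfavourable end. The entering group is again an aromatic ring, but a different one from the methoxyphenyl that leaves, and its heavy-atom count lies between those of the substituents of compound 2 and compound 3. A modest move back toward compound 2 is therefore expected, though a result within the scatter of compound 3 is also plausible; the expected step is a 2.1-fold lower number from compound 3 to compound 4 (0.31 log units; beyond the scatter). For compound 4 the estimate in this assay is 90 nM, with a range from 25 nM to 350 nM.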

Compound 4, half-maximal effective concentration: 24 nM
The estimate for compound 4 lay 3.8-fold (0.57 log units) above the measured number; the whole stated range lies above it.
By their numbers in this assay, from the lowest: compounds 1, 4 and 2 (each within the scatter of the next, the first and the last beyond it); then compound 3.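

In this assay an aromatic ring on the carbonyl carbon does not by itself go with the high number of compound 3: the 1,3-oxazol-5-yl group gives a 7.7-fold lower number from compound 3 to compound 4 (0.89 log units; beyond the scatter) and so limits the earlier trend, in which the number rose with each departure from ethyl, to compounds 1, 2 and 3. Compound 4 goes against that trend, and with a 1.6-fold higher number from compound 1 to compound 4 (0.20 log units; within the scatter) and a 1.9-fold lower number from compound 2 to compound 4 (0.28 log units; within the scatter) it cannot be told apart from either compound 1 or compound 2, so in this one case an aromatic ring at this position carries no measurable cost relative to the ethyl or 2-methylprop-1-en-1-yl group. The change alters ring size, heavy-atom count and hetero atoms together, and no evidence in hand separates these or explains the step.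

Still open, as far as these compounds go, is whether plain phenyl or pyridin-3-yl on the same carbonyl carbon would stand with compound 3 or with compound 4, which would show whether the methoxy group or the carbon-only ring goes with the higher number. Also open, from the compounds shown here alone, is how a longer alkyl chain or a dimethylamino group at this position would compare with the ethyl of compound 1.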